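The source may hold more compounds than are shown below. What is called first, only, known or untested is meant among the compounds shown, and "the series" means these compounds.

Three compounds of the series have numbers in a functional assay on MT2 cells (Homo sapiens) for cytotoxicity, read by MTT assay; a higher number here means that more compound is tolerated, a lower number that less compound is tolerated. Compound 1 `CC(C)=CCOc1cc(Nc2nccs2)ccc1C` gives 17000 nM; compound 2 `CC(C)=CCOc1cc(Nc2nccs2)ccc1C#N` gives 750 nM; compound 3 `CC(C)=CCOc1cc(Nc2ccccn2)ccc1C` gives 35000 nM. Compound 3 stands highest of the three numbers: the step of a 2.1-fold higher number from compound 1 to compound 3 (0.31 log units; beyond the scatter) is modest, while compound 2 lies far lower than compound 3. Compound 4 `CC(C)=CCOc1cc(Nc2ccccn2)ccc1C#N` has not been measured in this assay. It differs from compound 3 as follows: cyano in place of methyl on an aromatic carbon. The same change has been seen once in the series, in the step of a 23-fold lower number from compound 1 to compound 2 (1.36 log units; beyond the scatter), a large step well beyond the scatter. Going by the values given here, only that one pair bears on the question, and nothing in the data speaks against carrying it over, so a step of similar size and the same direction is expected in this assay, namely a 23-fold lower number from compound 3 to compound 4 (1.37 log units; beyond the scatter). Compound 4 is accordingly estimated to give 1500 nM in this assay, with an expected range from 500 nM to 5000 nM.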

Compound 4, half-maximal cytotoxic concentration: 290 nM
Beside the measured number, compound 4's estimate is 5.2-fold (0.71 log units) above it, and the stated range ends above it.
By their numbers in this assay, from the lowest: compound 4; then compound 2; then compound 1; then compound 3.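

In this assay, cyano in place of methyl on the aromatic carbon ortho to the (3-methylbut-2-en-1-yl)oxy group lowers the number on both cores, so the direction holds, but its size does not carry over unchanged, with a 120-fold lower number from compound 3 to compound 4 (2.08 log units; beyond the scatter): the same change on two cores in this assay, a 23-fold lower number (1.36 log units; beyond the scatter) from compound 1 to compound 2 and a 120-fold lower number (2.08 log units; beyond the scatter) from compound 3 to compound 4, 5.3-fold (0.73 log units) apart, beyond the scatter of two such steps

The exchange of 1,3-thiazol-2-yl for pyridin-2-yl also reverses direction once cyano is present, with a 2.6-fold lower number from compound 2 to compound 4 (0.41 log units; beyond the scatter): the same change on two cores in this assay, a 2.1-fold higher number (0.31 log units; beyond the scatter) from compound 1 to compound 3 and a 2.6-fold lower number (0.41 log units; beyond the scatter) from compound 2 to compound 4, 5.3-fold (0.73 log units) apart, beyond the scatter of two such steps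

The two places therefore do not act independently across these four compounds.

Going by these compounds, whether an amine or a carboxylic acid at this aromatic carbon would follow cyano or methyl stays open. Also open, on these data alone, is whether the same coupling survives when a longer chain replaces the (3-methylbut-2-en-1-yl)oxy group.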